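Replacing 1-(hydroxymethyl)cyclopropyl with piperidin-1-yl

A few compounds are considered here, and "the series" means these few. Any claim that something is new, unique, unknown or untested is made for them only; others in the source may bear on it.

compound 1 `COC(=O)C1(c2ccc(NC(=O)Nc3cccnc3Oc3ccccc3C(C)(C)C)cc2)CC1` measures 1 ug/mL
compound 2 `CC(C)(C)c1ccccc1Oc1ncccc1NC(=O)Nc1ccc(C2(CO)CC2)cc1` measures 5 ug/mL

Both numbers come from a physicochemical assay for solubility, in phosphate buffer, at pH 6.5 (on this read-out lower numbers stand for lower solubility and higher numbers for higher solubility), and are all that has been measured so far. Of the two, compound 2 stands higher with 5 ug/mL as its value, and compound 1 sits below it, a gap beyond the usual scatter.

Compound 3 `CC(C)(C)c1ccccc1Oc1ncccc1NC(=O)Nc1ccc(N2CCCCC2)cc1` differs from compound 2 in one place: piperidin-1-yl in place of 1-(hydroxymethyl)cyclopropyl on an aromatic carbon on an aromatic carbon of a six-membered aromatic ring of carbon only, para to a large group.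

Among the compounds with values here, only one measured step bears on this change. The step of a 5.0-fold higher number from compound 1 to compound 2 (0.70 log units; beyond the scatter) is modest and came with hydroxymethyl in place of methoxycarbonyl on a saturated ring carbon. Compound 3 gives up that same hydroxymethyl, along with the three-membered ring. Within the data shown here, no measured compound carries piperidin-1-yl, so this step is only a loose guide.

A modest fall is therefore expected in this assay and it may come close to the scatter. The estimated move is a 2.5-fold lower number from compound 2 to compound 3 (0.40 log units; beyond the scatter) and nothing much larger is expected. For compound 3 the estimated value is 2 ug/mL with 0.5 ug/mL to 6 ug/mL as its expected range.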

Compound 3, solubility: 9 ug/mL
Beside the measured number, compound 3's estimate is 4.5-fold (0.65 log units) below it; the whole stated range lies below it.
By their numbers in this assay, from the lowest: compound 1; then compounds 2 and 3 (each within the scatter of the next).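

In this assay, piperidin-1-yl in place of 1-(hydroxymethyl)cyclopropyl on this aromatic carbon gives a 1.8-fold higher number from compound 2 to compound 3 (0.26 log units; within the scatter), so the two groups cannot be told apart here, although the entering group carries 0 hydrogen-bond donors and the leaving group carries 1. The hydroxymethyl is therefore not required to reach this level in this pair, while the step from the methoxycarbonyl compound, a 9.0-fold higher number from compound 1 to compound 3 (0.95 log units; beyond the scatter), is modest and of a similar kind to the one seen earlier with hydroxymethyl. Nothing shown here explains why the numbers fall as they do.

The compounds shown leave open whether the six-membered ring, its nitrogen or neither goes with this level, which a morpholine ring, an open-chain dimethylamino group or a carboxylic acid on the same aromatic carbon could help to separate. With only piperidin-1-yl to represent groups attached through nitrogen at this place, they also cannot show whether other changes here would move the number beyond the scatter.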